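This account rests on a few compounds, and the source may have more. Where it says the series, first, only, none or still open, it means among the compounds named here.

Of the compounds shown here, three with the same core have been tested in a functional assay on MDA-MB-231 cells (Homo sapiens) for cytotoxicity, read by MTT assay, with a stated time of 72 h; a lower number here means a stronger inhibitor, a higher number a weaker inhibitor: compound 1 `O=C1c2c[n+]([O-])c3ccccc3c2C(=O)c2c1c1ccccc1n2Cc1cn([C@H]2O[C@H](CO)[C@@H](O)[C@H]2O)nn1` gives 1700 nM, compound 2 `O=C1c2c[n+]([O-])c3ccccc3c2C(=O)c2c1c1ccccc1n2Cc1cn([C@@H]2C[C@H](O)[C@@H](CO)O2)nn1` gives 130 nM, and compound 3 `O=C1c2c[n+]([O-])c3ccccc3c2C(=O)c2c1c1ccccc1n2Cc1cn(C[C@H](O)CO)nn1` gives 1310 nM. Compound 3 therefore sits in the upper part of this small range: a 1.3-fold lower number from compound 1 to compound 3 (0.11 log units; within the scatter) lies within the scatter, while a 10-fold higher number from compound 2 to compound 3 (1.00 log units; beyond the scatter) does not.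

Compound 4 `CC1(C)OCC(Cn2cc(Cn3c4c(c5ccccc53)C(=O)c3c[n+]([O-])c5ccccc5c3C4=O)nn2)O1` alters only the chain of compound 3, turning 2,3-dihydroxypropyl into (2,2-dimethyl-1,3-dioxolan-4-yl)methyl: 2,2-dimethyl-1,3-dioxolan-4-yl in place of 1,2-dihydroxyethyl on a saturated chain carbon bound to an aromatic nitrogen.

Going by the values given here, no measured step makes this exact change, so the guidance is indirect. The nearest case is the large 13-fold lower number from compound 1 to compound 2 (1.12 log units; beyond the scatter), where hydrogen replaces hydroxy on a saturated ring carbon. Against that, a 1.3-fold lower number from compound 1 to compound 3 (0.11 log units; within the scatter) shows that a very different group on the aromatic nitrogen need not shift the number at all. In this assay, a small move towards a lower number is therefore expected, possibly within the scatter. The expected change is a 1.6-fold lower number from compound 3 to compound 4 (0.21 log units; within the scatter). For compound 4 the estimated value is 800 nM, with an expected range of 250 nM to 2500 nM.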

Compound 4, half-maximal inhibitory concentration: 230 nM
The estimate for compound 4 lay 3.5-fold (0.54 log units) above the measured number; the whole stated range lies above it.
By their numbers in this assay, from the lowest: compounds 2 and 4 (each within the scatter of the next); then compounds 3 and 1 (each within the scatter of the next).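

In this assay, the step for this change (a 5.7-fold lower number from compound 3 to compound 4 (0.76 log units; beyond the scatter)) shows that the group on this saturated chain carbon bound to an aromatic nitrogen can matter: 1,2-dihydroxyethyl, with its hydrogen-bond donors, gives way to 2,2-dimethyl-1,3-dioxolan-4-yl, which has none, and the number moves beyond the scatter. Compared with the two sugar-type groups, the new group gives a step within the scatter in one case (a 1.8-fold higher number from compound 2 to compound 4 (0.25 log units; within the scatter)) and beyond it in the other (a 7.4-fold lower number from compound 1 to compound 4 (0.87 log units; beyond the scatter)), so an open chain bearing this ring can perform on a par with the better of them. Nothing given here explains these shifts.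

As far as these compounds go, it remains open whether the ring, its two methyl groups or the capping of both hydroxy groups accounts for the step. A 2,3-dimethoxypropyl chain and a 1,3-dioxolan-4-ylmethyl group without the methyl groups would help to separate these possibilities.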